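Two Chlorines Replace a Methoxy Group on the Aromatic Nitrogen

A few compounds are considered here, and "the series" means these few. Any claim that something is new, unique, unknown or untested is made for them only; others in the source may bear on it.

Compound 1 `Oc1cc(C(F)(F)F)ccc1-c1nc(-c2ccccc2O)n(-c2ccc(Br)cc2)n1` and compound 2 `COc1cccc(-n2nc(-c3ccc(C(F)(F)F)cc3O)nc2-c2ccccc2O)c1` share a core and differ only in the ring carried on an aromatic nitrogen. In a functional assay on PC-12 cells (Rattus norvegicus) for cytotoxicity, read by MTT assay, with stated times of 2 h and 24 h, tested at 1 uM (a higher number here means a stronger effect of the compound at the concentration tested, a lower number a weaker effect), compound 1 gives 69.4%, and in this assay compound 2 gives 68.3%. Compound 2 stands beside compound 1 on these numbers: the step of a number 1.1 percentage points lower from compound 1 to compound 2 (within the scatter) is within the scatter, so the two compounds cannot be told apart by this reading.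

Compound 3 `Oc1cc(C(F)(F)F)ccc1-c1nc(-c2ccccc2O)n(-c2ccc(Cl)cc2Cl)n1` has not yet been measured. It differs from compound 2 as follows: 2,4-dichlorophenyl in place of 3-methoxyphenyl on an aromatic nitrogen

Among the compounds with values here, the only measured step that bears on this change is the one from compound 1 to compound 2, which also exchanged the ring on that same aromatic nitrogen and stayed within the scatter. Within the data shown here, nothing measured so far points to a step beyond the scatter when one such ring is swapped for another. Compound 3 is therefore expected to give a number close to that of compound 2, with a step of a number 0.3 percentage points lower from compound 2 to compound 3 (within the scatter) that is within the scatter. The estimate for compound 3 in this assay is 68%, with a range from 55% to 80%.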

Compound 3, a percentage reported as activity, at one concentration (the size of the read-out at that concentration, not a potency): 69%
Compound 3: the middle estimate sits 1 percentage points below what was measured, and the stated range covers the measured number.
By their numbers in this assay, from the lowest: compounds 2, 3 and 1 (each within the scatter of the next).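

In this assay, putting 2,4-dichlorophenyl on the aromatic nitrogen in place of 3-methoxyphenyl gives a number 0.7 percentage points higher from compound 2 to compound 3 (within the scatter), and putting it there in place of 4-bromophenyl gives a number 0.4 percentage points lower from compound 1 to compound 3 (within the scatter). Within the data shown here, the earlier pair offered only one exchange at this position, whereas three rings can now be compared there, carrying a bromine, a methoxy group or two chlorines, and this reading cannot tell any of them apart, even though the 3-methoxyphenyl group counts one hydrogen-bond acceptor and the 2,4-dichlorophenyl group none. Nothing measured on these compounds offers an explanation for this lack of separation.

From the compounds shown here alone, all three compounds carry a substituted phenyl ring on this nitrogen, so it remains open whether a carboxylic acid, an amine or a longer alkyl chain at the same place would move the number beyond the scatter. Also open, going by these compounds, is whether the three compounds would still look alike at other concentrations, and whether changing the trifluoromethyl group or either hydroxyl group on the shared core would alter the reading.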